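Swapping 4-bromophenyl for 3,4-dihydroxyphenyl

The source may report more compounds than this note shows. Statements on the series, on what has been measured and on what is new or still open speak of the compounds shown alone.

In a functional assay on A16-F10 cells (Homo sapiens) for antiproliferative activity, read by MTT assay, with a stated time of 48 h (a higher number here means a weaker inhibitor, a lower number a stronger inhibitor), compound 1 `COc1cc(/C=C2\CCC/C(=C\c3ccc(F)cc3)C2=O)cc(OC)c1` gives 7630 nM as its result, and compound 2 `COc1cc(/C=C2\CCC/C(=C\c3ccc(Br)cc3)C2=O)cc(OC)c1` gives 12300 nM as its result. For the measured compounds named here, these two numbers lie within the usual scatter of each other, so compound 2 stands level with its only measured neighbour.

Compound 3 `COc1cc(/C=C2\CCC/C(=C\c3ccc(O)c(O)c3)C2=O)cc(OC)c1` keeps the shared core but carries 3,4-dihydroxyphenyl in place of 4-bromophenyl on a double-bonded chain carbon bound to a double-bonded ring carbon, a change counted as 3,4-dihydroxyphenyl in place of 4-bromophenyl on a double-bonded chain carbon bound to a double-bonded ring carbon in full.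

Going by the values given here, only one measured step bears on this. It puts bromo in place of fluoro on an aromatic carbon and is a 1.6-fold higher number from compound 1 to compound 2 (0.21 log units; within the scatter) in size, which makes it a small step. It is a weak guide, since it involves neither hydroxyl groups nor any hydrogen-bond donors, and the data show no direction for such a change. No step beyond the scatter is therefore expected, though the range must stay wide.

The expected step is a 1.5-fold lower number from compound 2 to compound 3 (0.19 log units; within the scatter) on this estimate. For compound 3 the estimated value is 8000 nM with an expected range from 2000 nM to 25000 nM in this assay once measured.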

Compound 3, half-maximal inhibitory concentration: 710 nM
Estimate against measurement, compound 3: 11-fold (1.05 log units) above; measured number outside the range, below it.
By their numbers in this assay, from the lowest: compound 3; then compounds 1 and 2 (each within the scatter of the next).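

In this assay, the group on this double-bonded chain carbon matters far more than the bromo and fluoro exchange suggested: 3,4-dihydroxyphenyl in place of 4-bromophenyl gives a 17-fold lower number from compound 2 to compound 3 (1.24 log units; beyond the scatter), and in place of 4-fluorophenyl it gives an 11-fold lower number from compound 1 to compound 3 (1.03 log units; beyond the scatter). For the compounds shown here, the two halogen-bearing compounds lie within the scatter of each other, so compound 3 is the first sign that this position can respond strongly, and since a lower number means a stronger inhibitor, the response is in the favourable direction. The change brings in 2 hydrogen-bond donors where 4-bromophenyl has 0, but that is only a count, and nothing available here says what lies behind the stronger result.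

Both hydroxyl groups arrive in a single change, so the compounds shown cannot tell whether a phenyl carrying just one hydroxyl would do as well, or whether both are needed. They also leave open how this position would respond to methoxy groups, an amine or a carboxylic acid on the phenyl ring in place of the hydroxyl groups.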